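The compounds below may be only part of what the source reports. "The series", "measured", "known", "first", "only" and "open" are said of these compounds alone.

Compound 1 `C#CCOc1cc(/C=C/C(=O)c2ccc(OC)c3c2OC(C)(C)C=C3)ccc1OC` carries a propargyl group on an oxygen on an aromatic ring. In a functional assay on A-375 cells (Homo sapiens) for cytotoxicity, read by MTT assay (a higher number here means a weaker inhibitor, a lower number a stronger inhibitor), compound 1 gives only a limit, > 10000 nM, not a number. Compound 2 `COc1ccc(/C=C/C(=O)c2ccc(OC)c3c2OC(C)(C)C=C3)cc1OC(=O)CCl`, with (chloromethyl)carbonyl in place of propargyl on that oxygen, gives 450 nM in this assay. That single change brought an at least 22-fold lower number from compound 1 to compound 2 (1.34 log units; beyond the scatter), a size that is only a lower bound because compound 1 sits at the limit of > 10000 nM in this assay, at which 1 of the 2 values shown sits. Compound 3 `COc1ccc(/C=C/C(=O)c2ccc(OC)c3c2OC(C)(C)C=C3)cc1OS(=O)(=O)c1ccc(C)cc1` alters the same oxygen in another way: (4-methylphenyl)sulfonyl in place of propargyl on an oxygen on an aromatic ring. Among the compounds with values here, only the step from compound 1 to compound 2 bears on this, and it was large and towards a lower number, so a step in the same direction is expected for compound 3 too, though the entering group is different and the size is uncertain. The expected step is an at least 3.3-fold lower number from compound 1 to compound 3 (0.52 log units; beyond the scatter). Compound 3 is therefore estimated to give about 3000 nM, within 500 nM to 15000 nM, in this assay.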

Compound 3, half-maximal inhibitory concentration: 2400 nM
For compound 3 the middle estimate is 1.3-fold (0.10 log units) above the measured one, within the range that was stated.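

In this assay a second group on this oxygen, (4-methylphenyl)sulfonyl, also gives a lower number than propargyl, with an at least 4.1-fold lower number from compound 1 to compound 3 (0.61 log units; beyond the scatter) in the record, so the drop is not confined to (chloromethyl)carbonyl. The two entering groups are not interchangeable, though, as the comparison between them shows a 5.3-fold higher number from compound 2 to compound 3 (0.73 log units; beyond the scatter) and so the choice of group on this oxygen matters. The step away from propargyl can only be read as a lower bound because compound 1 gives a limit and not a number: the limit of > 10000 nM in this assay, at which 1 of the 3 values shown sits.

The two active groups differ in many ways at once, so the compounds shown do not reveal which feature of them sets the number. An acetyl group, which lacks the chlorine of (chloromethyl)carbonyl, or a free hydroxyl on this oxygen would help to separate these features.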